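The compounds below may be only part of what the source reports. "The series", "measured", "known", "first", "only" and "open" are said of these compounds alone.

Measured compounds in an ADME assay on HFF cells (Homo sapiens) for cytotoxicity, read by MTT assay, with a stated time of 72 h; a higher number here means a weaker inhibitor, a lower number a stronger inhibitor:

- compound 1 `O=C1O[C@H]([C@@H](O)Cn2cc(CNS(=O)(=O)c3ccc(F)cc3)nn2)C(OCc2ccccc2)=C1OCc1ccccc1`: compound 1 gives 30 nM
- compound 2 `Cc1ccc(S(=O)(=O)NCc2cn(C[C@H](O)[C@H]3OC(=O)C(OCc4ccccc4)=C3OCc3ccccc3)nn2)cc1`: compound 2 gives 50 nM
- compound 3 `O=C1O[C@H]([C@@H](O)Cn2cc(CCO)nn2)C(OCc2ccccc2)=C1OCc1ccccc1`: compound 3 gives 58500 nM

Compound 3 stands highest of the three numbers in this assay; its step to each of the other two is beyond the scatter, the nearer being compound 2 and the further compound 1. Compounds 1 and 2 differ only in the aromatic substituent, and that step, a 1.7-fold higher number from compound 1 to compound 2 (0.22 log units; within the scatter), is within the scatter.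

The next compound, compound 4 `O=C1O[C@H]([C@@H](O)Cn2cc(CNS(=O)(=O)c3ccc(Cl)cc3F)nn2)C(OCc2ccccc2)=C1OCc1ccccc1`, is reached from compound 3 by ((4-chloro-2-fluorophenyl)sulfonyl)amino in place of hydroxymethyl on a saturated chain carbon bound to an aromatic carbon. This is the reverse of the change that separates compound 3 from the two sulfonamides: a 2000-fold higher number from compound 1 to compound 3 (3.29 log units; beyond the scatter) and a 1200-fold higher number from compound 2 to compound 3 (3.07 log units; beyond the scatter). Both of those steps are large and point the same way, and the aromatic substituent made little difference between compound 1 and compound 2. A step of comparable size in the opposite direction is therefore expected for compound 4, with only modest uncertainty added by the different aromatic substitution, so the expected step is a 1500-fold lower number from compound 3 to compound 4 (3.17 log units; beyond the scatter). Compound 4 is estimated at 40 nM, with a range from 10 nM to 160 nM.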

Compound 4, half-maximal inhibitory concentration: 20 nM
Compound 4: middle estimate off by 2.0-fold (0.30 log units), on the high side, within the range that was stated.
By their numbers in this assay, from the lowest: compounds 4, 1 and 2 (each within the scatter of the next, the first and the last beyond it); then compound 3.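

In this assay, the large gap between hydroxymethyl and the sulfonamides now also appears with a third sulfonyl group, and ((4-chloro-2-fluorophenyl)sulfonyl)amino in place of hydroxymethyl on the saturated chain carbon gives a 2900-fold lower number from compound 3 to compound 4 (3.47 log units; beyond the scatter) as the widest step in the set. Among the compounds shown here, on the sulfonyl sulfur, 4-chloro-2-fluorophenyl in place of 4-methylphenyl gives a 2.5-fold lower number from compound 2 to compound 4 (0.40 log units; beyond the scatter) as the first change of the aromatic part beyond the scatter, whereas 4-chloro-2-fluorophenyl in place of 4-fluorophenyl gives a 1.5-fold lower number from compound 1 to compound 4 (0.18 log units; within the scatter) and leaves those two compounds indistinguishable. Changes on the sulfonyl sulfur therefore register here, but they stay small beside the step from hydroxymethyl.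

A carboxamide or a simple amine on the same saturated chain carbon would separate the part played by the sulfonyl group from that of the aromatic ring, and methoxy or nitrile on that ring would test how far aromatic substitution can move the number. No measurement at hand gives a reason for the size of the step from hydroxymethyl or for the small differences among the sulfonamides.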